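The compounds below may be only part of what the source reports. "The series", "measured", "known", "first", "only" and "open" are said of these compounds alone.

Compound 1 `COc1cc2c(Oc3ccc(NC(=O)c4nn(-c5ccc(Br)cc5)c(=O)c5ccccc45)cc3F)ccnc2cc1OCCCN1CCCC1`: 180 nM
Compound 2 `COc1ccc(-n2nc(C(=O)Nc3ccc(Oc4ccnc5cc(OCCCN6CCCC6)c(OC)cc45)c(F)c3)c3ccccc3c2=O)cc1`: 1650 nM

In a functional assay on NCI-H460 cells (Homo sapiens) for cytotoxicity, read by MTT assay, with a stated time of 72 h (a lower number here means a stronger inhibitor, a higher number a weaker inhibitor), compound 1 holds the lowest of the two numbers; its nearest neighbour is compound 2, reached by a 9.2-fold higher number from compound 1 to compound 2 (0.96 log units; beyond the scatter). That step, a methoxy in place of bromo on an aromatic carbon, is the only one measured, and it touches a different part of the shared core from the change now at hand.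

Compound 3 `COc1cc2c(Oc3ccc(NC(=O)c4nn(-c5ccc(Br)cc5)c(=O)c5ccccc45)cc3F)ccnc2cc1OCCCN1CCC(C)CC1` has not yet been measured. It differs from compound 1 by 4-methylpiperidin-1-yl in place of pyrrolidin-1-yl on a saturated chain carbon, three bonds along the chain from an oxygen on an aromatic ring. Within the data shown here, no measured step bears on this exchange at the end of the chain, so the measured compounds give no direction for it. The expectation is therefore a step within the scatter, in either direction, from compound 1 to compound 3, that is a 1.1-fold higher number from compound 1 to compound 3 (0.05 log units; within the scatter). Compound 3 is estimated at 200 nM, with a range from 70 nM to 600 nM.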

Compound 3, half-maximal inhibitory concentration: 350 nM
Estimate against measurement, compound 3: 1.8-fold (0.24 log units) below, within the range that was stated.
By their numbers in this assay, from the lowest: compounds 1 and 3 (each within the scatter of the next); then compound 2.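

The end of the chain, three bonds along from the oxygen on the aromatic ring, proves to accept a sizeable exchange of its amine. In this assay, replacing the five-membered pyrrolidin-1-yl ring with the six-membered, methyl-bearing 4-methylpiperidin-1-yl ring gives a 1.9-fold higher number from compound 1 to compound 3 (0.29 log units; within the scatter), so the compounds shown separate no preference between these two amines. The only step shown beyond the scatter remains the one at the bromo position on the aromatic ring, and no measurement available here accounts for either step.

Going by these compounds, whether an amine such as morpholine or N-methylpiperazine, or an unsubstituted piperidine, would behave in the same way at this chain end stays open. So does the effect of a shorter or longer chain, and whether this exchange would read alike with methoxy in place of bromo.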